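Fluoro to bromo exchange: notes toward compound 4

A few compounds are considered here, and "the series" means these few. Any claim that something is new, unique, unknown or untested is made for them only; others in the source may bear on it.

Of the compounds shown here, three of the shared core have been measured in an assay on isolated protein for inhibition of protein kinase C zeta type (Homo sapiens), with a stated time of 4 min, tested at 62.5 uM; a higher number here means more inhibition at the concentration tested (going by the name of the read-out), a lower number less inhibition. Compound 1 `CC(C)(C)C1=NN(c2ccc(C(=O)O)cc2)C(c2ccc(O)cc2)C1` gives 47.9%. Compound 2 `COc1ccccc1C1=NN(c2ccc(Cl)cc2)C(c2ccc(O)cc2)C1` gives 68.4%. Compound 3 `CC(C)(C)C1=NN(c2ccc(Cl)cc2)C(c2ccc(F)cc2)C1` gives 0%. Compound 3 thus stands lowest of the three: compound 1 lies nearest, with a number higher by a margin beyond the scatter, and compound 2 lies furthest, also higher by a margin beyond the scatter. For the measured compounds named here, no two measured compounds differ in a single place, so no step between them can be read off directly.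

Compound 4 `CC(C)(C)C1=NN(c2ccc(Cl)cc2)C(c2ccc(Br)cc2)C1` is the unmeasured neighbour of compound 3. The change is bromo in place of fluoro on an aromatic carbon, on an aromatic carbon of a six-membered aromatic ring of carbon only, para to a large group. Going by the values given here, nothing among the measured compounds isolates this exchange, so the expectation rests on the low standing of compound 3 alone. The step from compound 3 to compound 4 in this assay is expected to be small, a number 10 percentage points higher from compound 3 to compound 4 (within the scatter), at most at the edge of the scatter. Compound 4 is accordingly estimated at 10%, with a range from 0% to 35%.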

Compound 4, a percentage reported as inhibition, at one concentration (the size of the read-out at that concentration, not a potency): 39%
Compound 4: middle estimate off by 29 percentage points, on the low side; measured number outside the range, above it.
By their numbers in this assay, from the lowest: compound 3; then compounds 4 and 1 (each within the scatter of the next); then compound 2.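

In this assay, for the compounds shown here, bromo in place of fluoro on an aromatic carbon gives a number 39 percentage points higher from compound 3 to compound 4 (beyond the scatter) and is the first single-place comparison. The position para to a large group therefore responds to the identity of the halogen, even though the change from 4-fluorophenyl to 4-bromophenyl leaves the counted hydrogen-bond donors and acceptors the same and the rest of the structure untouched. No supporting measurement bears on why the exchange has a step of this size.

From the compounds shown here alone, with only fluoro and bromo compared directly here, it remains open where chloro, an amine or a nitrile at this position would fall. Also open, going by these compounds, is whether the step would persist with a different group in place of the tert-butyl or 4-chlorophenyl parts.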